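This account rests on a few compounds, and the source may have more. Where it says the series, first, only, none or still open, it means among the compounds named here.

In an ADME assay on a cell-free system (plasma, Homo sapiens) for metabolic stability (a higher number here means that the compound lasts longer, a lower number that the compound disappears faster), compound 1 `CNc1[nH]c(=O)n(O)c(=O)c1C(=O)NCc1ccccc1` gives > 24 h, which is a limit of the assay and not a number. Compound 2 `CCNc1[nH]c(=O)n(O)c(=O)c1C(=O)NCc1cccc(Cl)c1F` gives > 24 h, and this too is a limit and not a number. Within the data shown here, compound 2 therefore stands with the only other measured compound, at the limit of > 24 h in this assay, at which 2 of the 2 values shown sit.

Compound 3 `CCNc1[nH]c(=O)n(O)c(=O)c1C(=O)NCc1ccc(C)c(F)c1` is the next compound to be tested, and it is built directly from compound 2. It carries 3-fluoro-4-methylphenyl in place of 3-chloro-2-fluorophenyl on a saturated chain carbon bound to an amide-type nitrogen. Everything else in compound 2 stays in place.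

Among the measured compounds shown here, no pair of measured compounds differs in only one place, so no measured step can serve as a guide for this swap. A step beyond the usual scatter is not expected in this assay, in either direction. This expectation rests on compound 2 and compound 1 both sitting at the limit of > 24 h in this assay, at which 2 of the 2 values shown sit. The estimated step that the limit leaves unreadable from compound 2 to compound 3 should therefore stay small. Compound 3 is expected at 30 h, with an estimated range of 15 h to 60 h, and the assay may well report only a limit.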

Compound 3, half-life in the Homo sapiens assay: > 24 h
Compound 3: only a limit was reported (the forecaster's own chance of this, stated with the estimate: 85%); the middle value is on the limit's open side.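

Compound 2 and compound 3 give only limits of the assay, not numbers, in the Homo sapiens assay. In a physicochemical assay for pharmacokinetics (on this read-out higher numbers stand for a longer-lived compound and lower numbers for a shorter-lived compound), compound 2 gives > 24 h, which is a limit of the assay and not a number. In the physicochemical assay compound 3 gives > 24 h, and this too is a limit and not a number. Among these compounds, no step between the two compounds can be read from these results. On these data alone, what stays open is the actual half-life of each compound, and whether 3-fluoro-4-methylphenyl in place of 3-chloro-2-fluorophenyl changes it at all.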